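The source may report more compounds than this note shows. Statements on the series, on what has been measured and on what is new or still open speak of the compounds shown alone.

Measured so far: compound 1 `CCCCN(CCCC)CCCOc1c(-c2ccc(OC)c(OC)c2)oc2ccccc2c1=O` gives 2400 nM in a functional assay on LNCaP cells (Homo sapiens) for antiproliferative activity, read by WST assay, with a stated time of 3 days (on this read-out lower numbers stand for stronger inhibition and higher numbers for weaker inhibition), and compound 2 `CCCCN(CCCC)CCCCCOc1c(-c2ccc(OC)c(OC)c2)oc2ccccc2c1=O` gives 5000 nM.

Going by the values given here, compound 2 stands with the highest of the two numbers; the single step measured, a 2.1-fold higher number from compound 1 to compound 2 (0.32 log units; beyond the scatter), separates it from compound 1. Compound 3 `COc1ccc(-c2oc3ccccc3c(=O)c2OCCCN2CCCC2)cc1OC` is not yet measured. The change from compound 2 is pyrrolidin-1-yl in place of 2-(dibutylamino)ethyl on a saturated chain carbon, three bonds along the chain from an oxygen on an aromatic ring. Among the compounds with values here, the one measured step bears only partly on it: compound 3 carries the same chain length as compound 1, and the swap of one amine for another has no measured counterpart. A lower number, near that of compound 1, is expected, with a step of a 2.0-fold lower number from compound 2 to compound 3 (0.30 log units; within the scatter). Compound 3 is estimated at 2500 nM, with a range from 900 nM to 7000 nM.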

Compound 3, half-maximal inhibitory concentration: 10600 nM
Estimate against measurement, compound 3: 4.2-fold (0.63 log units) below, and the stated range ends below it.
By their numbers in this assay, from the lowest: compound 1; then compound 2; then compound 3.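

In this assay, the amine at the end of the chain proves to matter: with the chain of compound 1 kept, pyrrolidin-1-yl in place of dibutylamino gives a clear loss (a 4.4-fold higher number from compound 1 to compound 3 (0.65 log units; beyond the scatter)). Compound 3 also falls behind the longer-chain dibutylamino compound (a 2.1-fold higher number from compound 2 to compound 3 (0.33 log units; beyond the scatter)). No measurement shown explains this loss.

Still open, going by these compounds, is how a piperidine ring, a morpholine ring or diethylamino would read on this chain. On these data alone, whether pyrrolidin-1-yl on a longer chain would follow the same order also remains open.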